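The source may report more compounds than this note shows. Statements on the series, on what has been measured and on what is new or still open speak of the compounds shown alone.

Measured in a functional assay on WI-38 VA13 cells (Homo sapiens) for cytotoxicity; on this read-out higher numbers stand for an effect only at larger amounts of compound and lower numbers for an effect already at smaller amounts:
Compound 1 `N#Cc1cccc(C(=O)Nc2ccc3nc(NC(=O)C4CCCCC4)sc3c2)c1`: 0.52 ug/mL
Compound 2 `O=C(Nc1ccc2nc(NC(=O)C3CCCCC3)sc2c1)c1cccc(Oc2ccccc2)c1`: > 4 ug/mL

Among the compounds with values here, compound 1 holds the only actual number among the measured compounds, at 0.52 ug/mL. The entry for compound 2, > 4 ug/mL, is a limit of the assay and not a number.

Compound 3 `O=C(Nc1ccc2nc(NC(=O)C3CCCCC3)sc2c1)c1c(Cl)cccc1Cl` has not yet been measured in this assay. Compared with compound 1, it carries 2,6-dichlorophenyl in place of 3-cyanophenyl on a carbonyl carbon. Within the data shown here, one measured step bears on this change, and only in part. That step is an at least 7.6-fold higher number from compound 1 to compound 2 (0.88 log units; beyond the scatter), with phenoxy in place of cyano on an aromatic carbon. The cyano group leaves in both changes, but a different group enters, so this step sets a direction more firmly than a size. A moderate rise in the number is therefore expected, probably smaller than the step seen with phenoxy, and it may not clear the usual scatter by much. The expected step is a 2.9-fold higher number from compound 1 to compound 3 (0.46 log units; beyond the scatter). Compound 3 is estimated at 1.5 ug/mL, with an expected range from 0.4 ug/mL to 6 ug/mL.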

Compound 3, half-maximal effective concentration: 0.015 ug/mL
Compound 3: middle estimate off by 100-fold (2.00 log units), on the high side, outside the stated range (below it).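

In this assay, 2,6-dichlorophenyl in place of 3-cyanophenyl on the carbonyl carbon gives a 35-fold lower number from compound 1 to compound 3 (1.54 log units; beyond the scatter), so the loss of the cyano group does not by itself raise the number. The earlier step, an at least 7.6-fold higher number from compound 1 to compound 2 (0.88 log units; beyond the scatter), ran the other way, which shows that at this part of the molecule the direction of the change depends on what enters and not only on what leaves. The entry for compound 2 remains a limit and not a number, so the full span of values reached by these changes cannot be sized: the limit of > 4 ug/mL in this assay, at which 1 of the 3 values shown sits.

The compounds shown do not separate the contribution of each chlorine in compound 3, and they leave open whether a ring with a single chlorine or with methyl groups in place of the chlorines would keep the number measured for compound 3, 0.015 ug/mL. They also leave open how an amine or a carboxylic acid on this ring would read in this assay, and whether the large step from the 2,6-dichlorophenyl group would carry over to a change elsewhere on the shared core.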